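Nitro position on the sulfonyl aryl of compound 1

The source may report more compounds than this note shows. Statements on the series, on what has been measured and on what is new or still open speak of the compounds shown alone.

In a functional assay on MCF7 cells (Homo sapiens) for antiproliferative activity (on this read-out lower numbers stand for stronger inhibition and higher numbers for weaker inhibition), compound 1 `O=c1cc[nH]c(=O)n1C1CN(S(=O)(=O)c2ccccc2[N+](=O)[O-])c2ccccc2CO1` gives 50900 nM, the highest number of the three measured. Compound 2 `O=[N+]([O-])c1ccccc1S(=O)(=O)N1CC(n2cnc3ncnc(O)c32)OCc2ccccc21` gives 19700 nM and compound 3 `O=[N+]([O-])c1ccccc1S(=O)(=O)N1CC(n2cnc3ncnc(Cl)c32)OCc2ccccc21` gives 920 nM. All measured steps act on the group carried by the saturated ring carbon: a 2.6-fold lower number from compound 1 to compound 2 (0.41 log units; beyond the scatter), a 55-fold lower number from compound 1 to compound 3 (1.74 log units; beyond the scatter) and a 21-fold lower number from compound 2 to compound 3 (1.33 log units; beyond the scatter). Compound 4 `O=c1cc[nH]c(=O)n1C1CN(S(=O)(=O)c2ccc([N+](=O)[O-])cc2)c2ccccc2CO1` differs from compound 1 elsewhere, with 4-nitrophenyl in place of 2-nitrophenyl on a sulfonyl sulfur. Going by the values given here, no measured step touches the aryl group on the sulfonyl sulfur, so nothing among the three compounds indicates a direction for this change; the expected step is none beyond the scatter, a 1.0-fold lower number from compound 1 to compound 4 (0.01 log units; within the scatter). Compound 4 is therefore estimated at 50000 nM in this assay, with a range of 15000 nM to 160000 nM.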

Compound 4, half-maximal inhibitory concentration: 44300 nM
Beside the measured number, compound 4's estimate is 1.1-fold (0.05 log units) above it, and the stated range covers the measured number.
By their numbers in this assay, from the lowest: compound 3; then compound 2; then compounds 4 and 1 (each within the scatter of the next).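

In this assay the aryl group on the sulfonyl sulfur now has a measured step: a 1.1-fold lower number from compound 1 to compound 4 (0.06 log units; within the scatter), with 4-nitrophenyl in place of 2-nitrophenyl. On the core of compound 1, this change of nitrophenyl isomer therefore does not separate the two numbers, whereas the group on the saturated ring carbon does give steps beyond the scatter. No evidence on the origin of this result is available.

Open, from the compounds shown here alone, is whether the isomer change stays as small with the chloro-bearing group of compound 3. Also open, going by these compounds, is what an amine or a carboxylic acid in place of the nitro group would do.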